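Swapping the aryl on a triazole: still no HUVEC growth inhibition

This account rests on a few compounds, and the source may have more. Where it says the series, first, only, none or still open, it means among the compounds named here.

Compound 2 `CCOc1ccccc1-n1nncc1CN1C(=O)C2(C(C#N)=C(N)Oc3c(N)cc4nc5ccccc5nc4c32)c2ccccc21` was tested in an ADME assay on HUVEC cells (Homo sapiens) for antiproliferative activity, read by MTT assay, with a stated time of 48 h; a higher number here means a weaker inhibitor, a lower number a stronger inhibitor. In this assay compound 2 gives > 50000 nM, which is a limit of the assay rather than a number. Compound 1 `COc1ccc(-n2nncc2CN2C(=O)C3(C(C#N)=C(N)Oc4c(N)cc5nc6ccccc6nc5c43)c3ccccc32)cc1` shares the same core, and in this assay compound 1 gives > 50000 nM, also a limit. The step that the two limits leave unreadable from compound 1 to compound 2 therefore cannot be read, as the limit of > 50000 nM in this assay, at which 2 of the 2 values shown sit, shows. Compound 3 `Cc1ccc(-n2nncc2CN2C(=O)C3(C(C#N)=C(N)Oc4c(N)cc5nc6ccccc6nc5c43)c3ccccc32)cc1C` differs from compound 2 by 3,4-dimethylphenyl in place of 2-ethoxyphenyl on an aromatic nitrogen. Among the compounds with values here, no measured step reads on this change, so no shift beyond the scatter is expected. The expected step is a number no higher from compound 2 to compound 3 (the limit leaves the size open). Compound 3 is estimated at 50000 nM, within 20000 nM to 150000 nM, most likely again only a limit.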

Compound 3, half-maximal inhibitory concentration: > 50000 nM
Compound 3 ended at the assay's limit; the forecaster's own chance of this, stated with the estimate: 80%; the middle value lies on the limit itself.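

No step among compound 1, compound 2 and compound 3 can be read, because each gives only a limit and not a number: the limit of > 50000 nM in this assay, at which 3 of the 3 values shown sit.

The compounds shown leave open how strongly each inhibits in this assay, and whether changing the aryl group on the aromatic nitrogen makes any difference.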